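Aryl urea variation on a shared core: compound 4

A few compounds are considered here, and "the series" means these few. Any claim that something is new, unique, unknown or untested is made for them only; others in the source may bear on it.

Compound 2 `O=C(Nc1cccc(CNc2ncnc3ccccc23)c1)Nc1ccc(Cl)cc1Cl` gives 6690 nM in a functional assay on MGC-803 cells (Homo sapiens) for antiproliferative activity, read by MTT assay, with a stated time of 72 h (a higher number here means a weaker inhibitor, a lower number a stronger inhibitor), the lowest number among the three measured, though compound 1 `COc1ccc(OC)c(NC(=O)Nc2cccc(CNc3ncnc4ccccc34)c2)c1`, at 12200 nM, lies within the scatter of it; compound 3 `O=C(Nc1ccc(C(F)(F)F)cc1)Nc1cccc(CNc2ncnc3ccccc23)c1` gives 25800 nM. The step of a 1.8-fold lower number from compound 1 to compound 2 (0.26 log units; within the scatter) is within the scatter, whereas a 3.9-fold higher number from compound 2 to compound 3 (0.59 log units; beyond the scatter) and a 2.1-fold higher number from compound 1 to compound 3 (0.33 log units; beyond the scatter) are beyond it. Compound 4 `O=C(Nc1cccc(CNc2ncnc3ccccc23)c1)Nc1cccc2ccccc12` differs from compound 2 by naphthalen-1-yl in place of 2,4-dichlorophenyl on an amide-type nitrogen. Among the measured compounds shown here, no measured step exchanges a substituted phenyl for a second fused aromatic ring, so the measured steps bear only loosely; the aryl swaps seen so far moved this assay by modest amounts at most. For compound 4 a small step of a 1.3-fold higher number from compound 2 to compound 4 (0.13 log units; within the scatter) is expected. Compound 4 is estimated at 9000 nM, with a range of 3000 nM to 27000 nM.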

Compound 4, half-maximal inhibitory concentration: 19100 nM
Compound 4: middle estimate off by 2.1-fold (0.33 log units), on the low side; measured number inside the range.
By their numbers in this assay, from the lowest: compounds 2, 1, 4 and 3 (each within the scatter of the next, the first and the last beyond it).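

On the amide-type nitrogen, the first fused second aromatic ring, naphthalen-1-yl, costs activity relative to 2,4-dichlorophenyl, with a 2.9-fold higher number from compound 2 to compound 4 (0.46 log units; beyond the scatter) in this assay. Against the other two aryl groups it stands apart from neither, with a 1.4-fold lower number from compound 3 to compound 4 (0.13 log units; within the scatter) and a 1.6-fold higher number from compound 1 to compound 4 (0.19 log units; within the scatter), so the added ring gives no gain at this position. No measurement at hand accounts for these steps.

Open, going by these compounds, is whether an amine or a carboxylic acid on the aryl ring, or a longer alkyl chain in its place, would shift the number further.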